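A Second Methoxy Added to a Compound Already at the Limit

This account rests on a few compounds, and the source may have more. Where it says the series, first, only, none or still open, it means among the compounds named here.

Of the compounds shown here, three built on one shared core have been tested in a functional assay on HepG2 cells (Homo sapiens) for antiproliferative activity, read by MTT assay, with a stated time of 24 h; on this read-out higher numbers stand for weaker inhibition and lower numbers for stronger inhibition. Compound 1 `c1ccc(C2=NN(c3ccc(-c4ccccc4)nn3)C(c3ccccc3)C2)cc1` gives 10000 nM. Compound 2 `Clc1ccc(C2CC(c3ccccc3)=NN2c2ccc(-c3ccccc3)nn2)cc1` carries chloro in place of hydrogen on an aromatic carbon and gives 6310 nM; the change from one to the other is a 1.6-fold lower number from compound 1 to compound 2 (0.20 log units; within the scatter). Compound 3 `COc1ccc(C2CC(c3ccccc3)=NN2c2ccc(-c3ccccc3)nn2)cc1` is reported only as a limit of the assay rather than as a number, namely > 100000 nM. Compound 3 therefore sits at the limit of > 100000 nM in this assay, at which 1 of the 3 values shown sits, the weakest point the numbers shown can reach. Two measured steps lead to it: an at least 10-fold higher number from compound 1 to compound 3 (1.00 log units; beyond the scatter) and an at least 15-fold higher number from compound 2 to compound 3 (1.19 log units; beyond the scatter), both clearly toward weaker inhibition when methoxy enters.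

Compound 4 `COc1ccc(C2CC(c3ccccc3)=NN2c2ccc(-c3ccccc3)nn2)c(OC)c1` is not yet measured. It differs from compound 3 by methoxy in place of hydrogen on an aromatic carbon, so a second methoxy joins the first on the same ring. Both measured steps in which methoxy entered moved the read-out a long way toward weaker inhibition, and compound 3 already stands at a limit, so the expected step that the limit leaves unreadable from compound 3 to compound 4 is most likely to keep compound 4 at or beyond that same limit, with a further number unlikely to appear. Compound 4 is expected to give about 150000 nM, somewhere between 50000 nM and 500000 nM.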

Compound 4, half-maximal inhibitory concentration: 100000 nM
The estimate for compound 4 lay 1.5-fold (0.18 log units) above the measured number, and the stated range covers the measured number.
By their numbers in this assay, from the lowest: compounds 2 and 1 (each within the scatter of the next); then compound 4.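

The second methoxy gives a number no higher from compound 3 to compound 4 (the limit leaves the size open). No size can be read for this step, because compound 3 is reported only as a limit of the assay rather than as a number: the limit of > 100000 nM in this assay, at which 1 of the 4 values shown sits.

What compound 4 adds is a real number for a methoxy-bearing ring in this assay, so the cost of this ring can now be sized against the other two compounds: a 16-fold higher number from compound 2 to compound 4 (1.20 log units; beyond the scatter) and a 10-fold higher number from compound 1 to compound 4 (1.00 log units; beyond the scatter). Both steps lie beyond the scatter and point toward weaker inhibition, so a methoxy placed ortho to a large group and meta to a methoxy group does not bring the series back to the level of compound 1 or compound 2.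

The compounds shown leave open whether a single methoxy at this new ring carbon, without the one already present in compound 3, would weaken inhibition to the same degree. They also leave open how the read-out would respond to a different group at that carbon, such as an amine, a carboxylic acid or a longer chain like butoxy.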